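Aryl swap on the sulfonamide: compound 2 to compound 3

The compounds below may be only part of what the source reports. "The series", "measured", "known", "first", "only" and "open" are said of these compounds alone.

Within the data shown here, in an assay on isolated protein for binding affinity to phosphatidylinositol 4,5-bisphosphate 3-kinase catalytic subunit beta isoform (Homo sapiens) (a higher number here means weaker binding, a lower number tighter binding), compound 2 `Nc1ncc(-c2cncc(NS(=O)(=O)c3ccc(F)cc3F)c2)cn1` gives 220 nM and is the only member of the set with a numerical result. For compound 1 `CC(=O)Nc1cncc(-c2cnc(N)nc2)c1` the read-out is a limit and not a number: > 20000 nM in this assay is where the series has the limit of > 20000 nM in this assay, at which 1 of the 2 values shown sits, sitting.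

Compound 3 `COc1ccc(S(=O)(=O)Nc2cncc(-c3cnc(N)nc3)c2)cc1` differs from compound 2 in one place, (4-methoxyphenyl in place of 2,4-difluorophenyl on a sulfonyl sulfur), that is 4-methoxyphenyl in place of 2,4-difluorophenyl on a sulfonyl sulfur. Among the measured compounds shown here, no measured pair isolates this swap. The step from compound 2 to compound 3 in this assay is expected to be modest and toward weaker binding, a 2.0-fold higher number from compound 2 to compound 3 (0.31 log units; beyond the scatter). Compound 3 is therefore expected near 450 nM in this assay with a range from 120 nM to 1600 nM.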

Compound 3, dissociation constant: 500 nM
Estimate against measurement, compound 3: 1.1-fold (0.05 log units) below; measured number inside the range.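

In this assay, the sulfonyl sulfur accepts 4-methoxyphenyl in place of 2,4-difluorophenyl with a modest change, a 2.3-fold higher number from compound 2 to compound 3 (0.36 log units; beyond the scatter), and binding remains a number and not a limit. Among these compounds, this is the first reading of the aryl group at this place. No measured property of either group bears on this step.

The compounds shown do not separate the loss of the two fluorines from the gain of the methoxy group. A plain phenyl or 4-fluorophenyl group would split the two, and a methyl group or an aminoethyl chain on the sulfonyl sulfur would test whether an aromatic ring is needed there.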